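Replacing the side chain of compound 2

A few compounds are considered here, and "the series" means these few. Any claim that something is new, unique, unknown or untested is made for them only; others in the source may bear on it.

Values in a functional assay on HCT-116 cells (Homo sapiens) for cytotoxicity, read by fluorescence, with a stated time of 72 h; a higher number here means a weaker inhibitor, a lower number a stronger inhibitor:
- compound 1 `CC(C)c1n[nH]c2c(NCc3ccc(-c4ccccn4)cc3)nc(S(C)(=O)=O)nc12`: 1140 nM
- compound 2 `CC(C)c1n[nH]c2c(NCc3ccc(-c4ccccn4)cc3)nc(NCC(C)(C)O)nc12`: 85 nM
- compound 3 `CC(C)c1n[nH]c2c(NCc3ccc(-c4ccccn4)cc3)nc(NCCN)nc12`: 227 nM

Compound 2, at 85 nM, holds the lowest number of the three in this assay. Two steps lead away from the methylsulfonyl compound: a 13-fold lower number from compound 1 to compound 2 (1.13 log units; beyond the scatter), and a 5.0-fold lower number from compound 1 to compound 3 (0.70 log units; beyond the scatter). Both amino side chains therefore gave lower numbers than methylsulfonyl, though by different amounts.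

The next compound to be tested is compound 4 `CC(C)c1n[nH]c2c(NCc3ccc(-c4ccccn4)cc3)nc(N[C@@H]3CCCC[C@H]3N)nc12`. It carries 2-aminocyclohexyl in place of 2-hydroxy-2-methylpropyl on a nitrogen on an aromatic ring.

The closest measured comparison is a 2.7-fold higher number from compound 2 to compound 3 (0.43 log units; beyond the scatter). There, too, a chain ending in an amine replaces the chain of compound 2, so this step points towards a somewhat higher number. Within the data shown here, no measured compound has a ring on this nitrogen, however, and the effect of the cyclohexyl ring and its two defined stereocentres remains unknown. The expectation is therefore of no step beyond the scatter, with a range that extends further upwards than downwards. The expected change is a 1.1-fold higher number from compound 2 to compound 4 (0.02 log units; within the scatter). For compound 4 the estimated value is 90 nM, with an expected range from 25 nM to 300 nM.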

Compound 4, half-maximal inhibitory concentration: 427 nM
Compound 4: the middle estimate sits 4.7-fold (0.68 log units) below what was measured; measured number above the stated range.
By their numbers in this assay, from the lowest: compound 2; then compounds 3 and 4 (each within the scatter of the next); then compound 1.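

In this assay the step to a ring on this nitrogen gave a 5.0-fold higher number from compound 2 to compound 4 (0.70 log units; beyond the scatter), so 2-aminocyclohexyl, with its one six-membered ring and its two defined stereocentres, did not keep the low number that 2-hydroxy-2-methylpropyl gives on the shared core. Measured against the open amine chain, the same group gave a 1.9-fold higher number from compound 3 to compound 4 (0.27 log units; within the scatter), a step within the scatter, so the ring cannot be told apart from 2-aminoethyl here, while a 2.7-fold lower number from compound 1 to compound 4 (0.43 log units; beyond the scatter) shows that (2-aminocyclohexyl)amino, like the other two amino side chains, still stands beyond the scatter on the low side of methylsulfonyl. Nothing available explains why compound 2 stands apart from the two side chains that end in an amine.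

The compounds shown leave open whether the ring or the terminal amine accounts for the step from compound 2, for compound 4 changes both at once, and a 2-hydroxycyclohexyl or a plain cyclohexyl group on the same nitrogen would separate the two. They also leave open what the two stereocentres contribute, as only one stereoisomer of 2-aminocyclohexyl appears among them.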